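Swapping the Methoxy Methyl for Phenyl in a Fatty Acid Agonist Series

The source may hold more compounds than are shown below. What is called first, only, known or untested is meant among the compounds shown, and "the series" means these compounds.

Three measured compounds share one core. In a functional assay on CHO cells for agonist activity at Free fatty acid receptor 1 (Homo sapiens), read by reporter gene assay (a lower number here means a smaller maximal response, a higher number a larger maximal response), compound 1 `O=C(O)CCc1ccc(NCc2ccc(C(F)(F)F)cc2)cc1` gives 133%. Compound 2 `O=C(O)CCc1ccc(NCc2ccc(O)cc2)cc1` gives 37%, and compound 3 `COc1ccc(CNc2ccc(CCC(=O)O)cc2)cc1` gives 159%, the highest of the three, reached through the steps of a number 26 percentage points higher from compound 1 to compound 3 (beyond the scatter) and a number 122 percentage points higher from compound 2 to compound 3 (beyond the scatter). Compound 4 `O=C(O)CCc1ccc(NCc2ccc(Oc3ccccc3)cc2)cc1` carries phenyl in place of methyl on an oxygen on an aromatic ring. The step that bears most on this change is the one already made at the same oxygen, a number 122 percentage points higher from compound 2 to compound 3 (beyond the scatter), which was large; the step of a number 26 percentage points higher from compound 1 to compound 3 (beyond the scatter) was modest. Both show that what hangs on this oxygen moves the maximal response strongly, yet neither tells which way a larger group on it goes, so a step of uncertain direction inside a wide band is expected. Compound 4 is therefore estimated at 140%, between 90% and 180%, meaning a number 19 percentage points lower from compound 3 to compound 4 (beyond the scatter).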

Compound 4, largest response reached (reported as percent of maximum), in percent of the reference or control that the assay uses: 139%
Compound 4: the middle estimate sits 1 percentage points above what was measured; the measured number falls inside the stated range.
By their numbers in this assay, from the lowest: compound 2; then compounds 1 and 4 (each within the scatter of the next); then compound 3.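

In this assay, a much larger group on this oxygen keeps a high maximal response: phenyl in place of methyl gives a number 20 percentage points lower from compound 3 to compound 4 (beyond the scatter) and phenyl in place of hydrogen gives a number 102 percentage points higher from compound 2 to compound 4 (beyond the scatter) in this series. Phenoxy in place of trifluoromethyl gives a number 6 percentage points higher from compound 1 to compound 4 (within the scatter) on the same core. Nothing available here explains these steps.

As far as these compounds go, whether ethyl or benzyl on this oxygen would keep the response near that of compound 3 or compound 4 remains open. So does the effect of pyridyl in place of phenyl.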